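A few compounds are considered here, and "the series" means these few. Any claim that something is new, unique, unknown or untested is made for them only; others in the source may bear on it.

Going by the values given here, in a functional assay on the whole organism (stomach) with Rattus norvegicus as the target (on this read-out higher numbers stand for an effect only at larger amounts of compound and lower numbers for an effect already at smaller amounts), only two compounds have numbers so far. Compound 1 `CCCc1ccc(C(=O)Nc2cc(C(=O)O)cc(C(=O)O)c2)cc1` gives 94.2 mg/kg, and compound 2 `N#Cc1ccc(C(=O)Nc2ccc(-c3nn[nH]n3)cc2)cc1` gives 54.4 mg/kg. These two numbers lie within the usual scatter of each other, so compound 1 cannot be set apart from compound 2 on what has been measured.

Compound 3 `O=C(O)c1ccc(C(=O)Nc2cc(C(=O)O)cc(C(=O)O)c2)cc1` keeps the core of compound 1 and alters one group, with carboxy in place of propyl on an aromatic carbon, para to a large group (carboxy in place of propyl on an aromatic carbon). Among the compounds with values here, no two measured compounds differ in a single place, so the data offer no measured step that could size this change. The nearest anchor is therefore compound 1 itself, at 94.2 mg/kg. On that basis, no step beyond the scatter is expected in this assay, and no direction is favoured. With so little to go on, the range has to stay wide. The estimated change is a 1.1-fold higher number from compound 1 to compound 3 (0.03 log units; within the scatter), which is expected to stay within the scatter. For compound 3 the expected value is 100 mg/kg, with an estimated range from 40 mg/kg to 250 mg/kg.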

Compound 3, dose for 50% inhibition: 32.2 mg/kg
Compound 3: middle estimate off by 3.1-fold (0.49 log units), on the high side, outside the stated range (below it).
By their numbers in this assay, from the lowest: compounds 3, 2 and 1 (each within the scatter of the next, the first and the last beyond it).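

Going by these compounds alone, with carboxy in place of propyl on an aromatic carbon, para to a large group, this assay gives the first step between compounds that differ in one place: a 2.9-fold lower number from compound 1 to compound 3 (0.47 log units; beyond the scatter), a modest step. This shows that the number responds to what this position carries on the core of compound 1, which the earlier pair, differing in more than one place, could not show. The leaving and entering groups both count 3 heavy atoms, while the carboxy group brings oxygen, a double bond, a hydrogen-bond donor and a hydrogen-bond acceptor, and nothing available shows which of these differences accounts for the step.

From the compounds shown here alone, it remains open how an amine, a methyl ester or a chain longer than propyl at this position would read in this assay, and so whether the step reflects something particular to the carboxy group or to the loss of propyl. Going by these compounds, it is also open whether the same exchange would give a step of similar size if the two carboxy groups of the shared core were replaced by a tetrazole.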